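The source may report more compounds than this note shows. Statements on the series, on what has been measured and on what is new or still open speak of the compounds shown alone.

In a functional assay on A549 cells (Homo sapiens) for inhibition, read by MTT assay, with a stated time of 24 h (a higher number here means a weaker inhibitor of growth, a lower number a stronger inhibitor of growth), compound 1 `Cn1cc(-c2nc3ccccc3n2C(=O)c2ccccc2)c2ccccc21` gives 19600 nM, compound 2 `COc1cccc(C(=O)n2c(-c3cn(C)c4ccccc34)nc3ccccc32)c1` gives 10200 nM and compound 3 `COc1ccc(C(=O)n2c(-c3cn(C)c4ccccc34)nc3ccccc32)cc1` gives 10400 nM, so compound 3 stands within the scatter of both others. Compound 4 `COc1ccc(C(=O)n2c(-c3cn(C)c4ccccc34)nc3ccccc32)cc1OC` differs from compound 3 by one change, (methoxy in place of hydrogen on an aromatic carbon), which turns 4-methoxyphenyl into 3,4-dimethoxyphenyl. Two measured steps made the same kind of exchange, methoxy in place of hydrogen on an aromatic carbon: a 1.9-fold lower number from compound 1 to compound 2 (0.28 log units; within the scatter) and a 1.9-fold lower number from compound 1 to compound 3 (0.28 log units; within the scatter). The swap of 3-methoxyphenyl for 4-methoxyphenyl gave a 1.0-fold higher number from compound 2 to compound 3 (0.01 log units; within the scatter). In this assay the expected step is a 1.2-fold lower number from compound 3 to compound 4 (0.09 log units; within the scatter), nothing beyond the scatter. For compound 4 the estimated value is 8500 nM, with an expected range of 3500 nM to 18000 nM.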

Compound 4, concentration for 50% growth inhibition: 3100 nM
Compound 4: the middle estimate sits 2.7-fold (0.44 log units) above what was measured, and the stated range ends above it.
By their numbers in this assay, from the lowest: compound 4; then compounds 2, 3 and 1 (each within the scatter of the next).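

In this assay, a methoxy group ortho to a methoxy group moved the number beyond the scatter, which neither single methoxy group had done against phenyl (a 3.4-fold lower number from compound 3 to compound 4 (0.53 log units; beyond the scatter); a 3.3-fold lower number from compound 2 to compound 4 (0.52 log units; beyond the scatter)). Measured from phenyl, 3,4-dimethoxyphenyl gives the largest step shown (a 6.3-fold lower number from compound 1 to compound 4 (0.80 log units; beyond the scatter)). Even so, the second methoxy group is not shown to count for more than the first: the same change on two cores in this assay, a 1.9-fold lower number (0.28 log units; within the scatter) from compound 1 to compound 2 and a 3.4-fold lower number (0.53 log units; beyond the scatter) from compound 3 to compound 4, 1.7-fold (0.24 log units) apart, within the scatter of two such steps.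

The compounds leave open whether this step is specific to methoxy or would also appear with a hydroxy group, an ethoxy group or an amine in the same place.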